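Ethoxy to Isopropoxy on the Benzyl Ether Tail

This account rests on a few compounds, and the source may have more. Where it says the series, first, only, none or still open, it means among the compounds named here.

Compound 1 `COc1cccc(OC)c1OCCNCCOc1ccccc1OCc1cccc(C)c1`: 8.85
Compound 2 `COc1cccc(OC)c1OCCNCCOc1ccccc1OCc1ccc(C)cc1`: 9.12
Compound 3 `CCOc1ccc(COc2ccccc2OCCNCCOc2c(OC)cccc2OC)cc1`: 9.11

In a functional assay on thoracic aorta for antagonist activity at Alpha-1D adrenergic receptor (Rattus norvegicus) (on this read-out lower numbers stand for lower potency and higher numbers for higher potency (the scale is a negative logarithm)), compound 3 gives 9.11, the second highest of the three numbers, though its gaps to compound 2 and to compound 1 both lie within the scatter. Compound 4 `COc1cccc(OC)c1OCCNCCOc1ccccc1OCc1ccc(OC(C)C)cc1` differs from compound 3 by methyl in place of hydrogen on a saturated chain carbon bound to an oxygen on an aromatic ring and a saturated chain carbon. Three measured steps change this same aryl group: a number 0.01 log units lower from compound 2 to compound 3 (within the scatter), a number 0.27 log units higher from compound 1 to compound 2 (within the scatter) and a number 0.26 log units higher from compound 1 to compound 3 (within the scatter), none beyond the scatter. The change to compound 4 is one more variation at that spot, so no step beyond the scatter is expected in this assay. Compound 4 is therefore estimated at 9.05, with a range from 8.65 to 9.45. The expected step is a number 0.06 log units lower from compound 3 to compound 4 (within the scatter).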

Compound 4, negative logarithm of the antagonist equilibrium constant: 9.14
For compound 4 the middle estimate is 0.09 log units below the measured one, within the range that was stated.
By their numbers in this assay, from the lowest: compounds 1, 3, 2 and 4 (each within the scatter of the next).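

In this assay the extra methyl that turns ethoxy into isopropoxy gives a number 0.03 log units higher from compound 3 to compound 4 (within the scatter) and so adds branching at this position without a step beyond the scatter. The isopropoxy tail also stays within the scatter of the two methylphenyl tails, with a number 0.02 log units higher from compound 2 to compound 4 (within the scatter) and a number 0.29 log units higher from compound 1 to compound 4 (within the scatter) so all four tails shown read alike. No supporting measurement offers an explanation for this result. On these data alone, whether an amine, a carboxylic acid or a longer chain such as butoxy on this aromatic ring would keep the number in the same range remains open.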